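Swapping the Indole on Compound 2 for a Chlorophenyl

The source may hold more compounds than are shown below. What is called first, only, known or untested is meant among the compounds shown, and "the series" means these compounds.

Of the compounds shown here, three built on one shared core have been tested in a functional assay on B16-F10 cells (Mus musculus) for cytotoxicity, read by MTT assay, with a stated time of 48 h; a lower number here means a stronger inhibitor, a higher number a weaker inhibitor. Compound 1 `O=C(/C=C\Nc1ccc(F)cc1)c1nc(-c2ccc(F)cc2)n2ccccc12` gives only a limit there, > 30000 nM. Compound 2 `O=C(/C=C\Nc1ccc2cc[nH]c2c1)c1nc(-c2ccc(C(F)(F)F)cc2)n2ccccc12` likewise gives only a limit in this assay, > 30000 nM. Among the measured compounds shown here, compound 3 `COc1ccc(N/C=C\C(=O)c2nc(-c3ccc(OC)cc3)n3ccccc23)cc1` is the one member with a real number, reaching 2120 nM in this assay. Compound 2 therefore stands at the limit of > 30000 nM in this assay, at which 2 of the 3 values shown sit, and carries no number that can be compared with anything else.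

Compound 4 `O=C(/C=C\Nc1ccc(Cl)cc1)c1nc(-c2ccc(C(F)(F)F)cc2)n2ccccc12` has not yet been measured. It differs from compound 2 in one place: 4-chlorophenyl in place of 1H-indol-6-yl on an amine nitrogen. For the measured compounds named here, no measured pair isolates this change, so its effect is open. Going by the values given here, the only other compound that lacks the indole while carrying a halogen on the phenyl at that nitrogen, compound 1, also reaches just a limit. The step from compound 2 is expected to be a number no higher from compound 2 to compound 4 (the limit leaves the size open), that is, no shift beyond the scatter. Compound 4 is estimated to land near 30000 nM, between 8000 nM and 100000 nM, most probably again as a limit.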

Compound 4, half-maximal inhibitory concentration: > 30000 nM
Compound 4: no number, only a limit; the forecaster's own chance of this, stated with the estimate: 65%; the middle value lies on the limit itself.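

Compound 4 gives > 30000 nM, which is a limit and not a number. Among the compounds shown here, compound 2 also gives only a limit, so no step between these two compounds can be read. The compounds shown leave open whether 4-chlorophenyl in place of 1H-indol-6-yl changes the result in this assay at all.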